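Notes on nitrogen substituents and growth inhibition in one series

The compounds below may be only part of what the source reports. "The series", "measured", "known", "first", "only" and "open" are said of these compounds alone.

compound 1 `CCOC(=O)CN(Cc1ccccc1)c1nc(NCc2ccccc2)ncc1[N+](=O)[O-]` — in a functional assay on HepG2 cells (Homo sapiens) for antiproliferative activity, read by MTT assay, with a stated time of 48 h (a lower number here means a stronger inhibitor, a higher number a weaker inhibitor), compound 1 gives 21000 nM.
compound 2 `CCOC(=O)CNc1nc(Nc2ccccc2)ncc1[N+](=O)[O-]` — in this assay compound 2 gives > 100000 nM, a limit of the assay and not a number.
compound 3 `CCOC(=O)CN(Cc1ccccc1)c1nc(Nc2ccccc2)ncc1[N+](=O)[O-]` — in this assay compound 3 gives 44400 nM.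

Compound 3 stands at the highest of the two numbers in this assay; its nearest neighbour is compound 1, separated by a 2.1-fold higher number from compound 1 to compound 3 (0.33 log units; beyond the scatter). Against the limit of compound 2 the step reads an at least 2.2-fold lower number from compound 2 to compound 3 (0.35 log units; beyond the scatter).

Compound 4 `CCOC(=O)CNc1ncc([N+](=O)[O-])c(N(CC(=O)OCC)Cc2ccccc2)n1` differs from compound 3 by (ethoxycarbonyl)methyl in place of phenyl on a nitrogen on an aromatic ring. Among the compounds with values here, no measured pair makes this exact exchange. Within the data shown here, the steps that bear on it are the phenyl-for-benzyl change a 2.1-fold higher number from compound 1 to compound 3 (0.33 log units; beyond the scatter) and the benzyl-for-hydrogen change an at least 2.2-fold lower number from compound 2 to compound 3 (0.35 log units; beyond the scatter), both modest. A modest step is therefore expected in this assay, its direction uncertain, with a lean toward a lower number as seen for compound 1 at 21000 nM. Compound 4 is expected to give 30000 nM, within 10000 nM to 100000 nM. The expected step is a 1.5-fold lower number from compound 3 to compound 4 (0.17 log units; within the scatter).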

Compound 4, half-maximal inhibitory concentration: 44500 nM
Compound 4: middle estimate off by 1.5-fold (0.17 log units), on the low side; measured number inside the range.
By their numbers in this assay, from the lowest: compound 1; then compounds 3 and 4 (each within the scatter of the next). At a limit, above all of these: compound 2.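

At this nitrogen, the ring-free (ethoxycarbonyl)methyl and the phenyl cannot be told apart in this assay (a 1.0-fold higher number from compound 3 to compound 4 (0.00 log units; within the scatter)), so an aromatic ring here is not needed to hold the number. Only the benzyl of compound 1 stands apart (a 2.1-fold higher number from compound 1 to compound 4 (0.33 log units; beyond the scatter)), and the change from it to either group costs the same modest step. No measurement shown gives a reason for this.

Still open, from the compounds shown here alone, is whether a carboxylic acid in place of the ethyl ester, or an amine on a longer chain, would move the number at this nitrogen. Going by these compounds, a substituted benzyl here also remains untested against compound 1.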